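This account rests on a few compounds, and the source may have more. Where it says the series, first, only, none or still open, it means among the compounds named here.

Working notes on the series. The three measured compounds share one core and differ only in the aryl group on the oxygen on the saturated carbon. Compound 1 `CC(C)(C)OC(=O)N1CCC(O[C@H]2CC[C@H](Oc3ccc(C#N)cc3)CC2)CC1` gives 116% in a functional assay on isolated protein for agonist activity at Glucose-dependent insulinotropic receptor (Homo sapiens), read by HTRF and cAMP accumulation; a higher number here means a larger maximal response, a lower number a smaller maximal response. Compound 2 `CC(C)(C)OC(=O)N1CCC(O[C@H]2CC[C@H](Oc3ccc(S(C)(=O)=O)cn3)CC2)CC1` gives 111%, and compound 3 `CC(C)(C)OC(=O)N1CCC(O[C@H]2CC[C@H](Oc3cnc(C#N)cn3)CC2)CC1` gives 110%. Compound 3 holds the lowest of the three numbers, yet both gaps lie within the scatter: a number 1 percentage points lower from compound 2 to compound 3 (within the scatter) and a number 6 percentage points lower from compound 1 to compound 3 (within the scatter). The remaining pair behaves the same way, a number 5 percentage points lower from compound 1 to compound 2 (within the scatter).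

Compound 4 `CC(C)(C)OC(=O)N1CCC(O[C@H]2CC[C@H](Oc3ccc(S(C)(=O)=O)nn3)CC2)CC1` is the next member. Its change from compound 3: 6-(methylsulfonyl)pyridazin-3-yl in place of 5-cyanopyrazin-2-yl on an oxygen on a saturated carbon

Within the data shown here, the steps that bear on this exchange are the three above, each within the scatter, including the swap between a methylsulfonyl-bearing and a nitrile-bearing heteroaryl from compound 2 to compound 3. No step beyond the scatter is therefore expected here; the estimated step is a number 2 percentage points higher from compound 3 to compound 4 (within the scatter). Compound 4 is estimated at 112%, with a range from 100% to 124%.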

Compound 4, largest response reached (Emax), in percent of the reference or control that the assay uses: 97%
Compound 4: middle estimate off by 15 percentage points, on the high side, and the stated range ends above it.
By their numbers in this assay, from the lowest: compound 4; then compounds 3, 2 and 1 (each within the scatter of the next).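

Among these compounds, the aryl group on this oxygen tolerates less variation than the earlier compounds suggested: in this assay the 6-(methylsulfonyl)pyridazin-3-yl group gives the first steps beyond the scatter, a number 13 percentage points lower from compound 3 to compound 4 (beyond the scatter) and a number 14 percentage points lower from compound 2 to compound 4 (beyond the scatter) and a number 19 percentage points lower from compound 1 to compound 4 (beyond the scatter). The methylsulfonyl group alone does not go with the lower response, since the step from compound 2 exchanges only the aromatic ring that carries this group, and compound 2 stays within the scatter of compound 1 and compound 3. No measurement bears on why this exchange lowers the maximal response.

As far as these compounds go, it remains open whether the lower response belongs to the pyridazin-3-yl ring itself or to its pairing with methylsulfonyl; a 6-cyanopyridazin-3-yl group would separate the two. From the compounds shown here alone, how a primary amide or an amine on that ring would fare is also open.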